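Benzyl for phenyl on the sulfur: compound 4

A few compounds are considered here, and "the series" means these few. Any claim that something is new, unique, unknown or untested is made for them only; others in the source may bear on it.

Measured so far:
compound 1 `COc1ccc(CCCCCCCCOc2ccc(CSc3cccc(C(=O)O)c3)nc2/C=C/C(=O)O)cc1` 1000 nM
compound 2 `COc1ccc(CCCCCCCCOc2ccc(CSCc3cccc(C(=O)O)c3)nc2/C=C/C(=O)O)cc1` 271 nM
compound 3 `COc1ccc(CCCCCCCCOc2ccc(CS(=O)(=O)Cc3cccc(C(=O)O)c3)nc2/C=C/C(=O)O)cc1` 1000 nM

In a functional assay on the whole organism with Homo sapiens as the target (on this read-out higher numbers stand for weaker inhibition and lower numbers for stronger inhibition), compound 1 gives 1000 nM, level with compound 3 within the scatter, and together these are the highest numbers of the three; compound 2 is the only one that sits lower. Among the compounds with values here, the one measured step that bears on the change in compound 4 is the phenyl-to-benzyl move already seen: a 3.7-fold lower number from compound 1 to compound 2 (0.57 log units; beyond the scatter), a modest gain. Compound 4 `COc1ccc(CCCCCCCCOc2ccc(CSCc3ccc(C(=O)O)cc3)nc2/C=C/C(=O)O)cc1` differs from compound 1 by 4-carboxybenzyl in place of 3-carboxyphenyl on a sulfur. That is the same phenyl-to-benzyl move, with the carboxylic acid shifted on the ring; nothing measured covers that shift alone. Expected is a step of similar kind, a 2.5-fold lower number from compound 1 to compound 4 (0.40 log units; beyond the scatter), giving compound 4 an estimated 400 nM, between 150 nM and 1200 nM.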

Compound 4, half-maximal inhibitory concentration: 426 nM
Compound 4: the middle estimate sits 1.1-fold (0.03 log units) below what was measured, and the stated range covers the measured number.
By their numbers in this assay, from the lowest: compounds 2 and 4 (each within the scatter of the next); then compounds 1 and 3 (each within the scatter of the next).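

In this assay, the gain from replacing 3-carboxyphenyl with a benzyl group on the sulfur holds for 4-carboxybenzyl as well as for 3-carboxybenzyl: a 2.3-fold lower number from compound 1 to compound 4 (0.37 log units; beyond the scatter). The two carboxybenzyl placements are not separated, with a 1.6-fold higher number from compound 2 to compound 4 (0.20 log units; within the scatter), so this read-out does not distinguish them. Nothing available accounts for either step.

Still open, on these data alone, is 4-carboxyphenyl on the sulfur, which would separate the effect of the added carbon from that of moving the carboxylic acid. Also open, as far as these compounds go, is a tetrazole in place of the carboxylic acid on the benzyl ring.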